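Cyclobutyl in place of the aryl group: compound 4

A few compounds are considered here, and "the series" means these few. Any claim that something is new, unique, unknown or untested is made for them only; others in the source may bear on it.

Values so far in an ADME assay on microsomes from liver (Mus musculus) for metabolic stability, with a stated time of 10 min (on this read-out lower numbers stand for a less stable compound and higher numbers for a more stable compound), for this series
- compound 1 `O=C(O)[C@H]1CC[C@H](C(=O)N2CC[C@](c3ccc(C(OCc4ccccc4OC(F)(F)F)(C(F)(F)F)C(F)(F)F)cc3)(S(=O)(=O)c3ccc(F)cc3)C2)CC1` gives 81% here
- compound 2 `Cc1cccc(F)c1COC(c1ccc([C@]2(S(=O)(=O)c3ccc(F)cc3)CCN(C(=O)[C@H]3CC[C@H](C(=O)O)CC3)C2)cc1)(C(F)(F)F)C(F)(F)F` gives 78% here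
- compound 3 `COc1cccc(F)c1COC(c1ccc([C@]2(S(=O)(=O)c3ccc(F)cc3)CCN(C(=O)[C@H]3CC[C@H](C(=O)O)CC3)C2)cc1)(C(F)(F)F)C(F)(F)F` gives 88% here

Compound 3 gives the top number of the three at 88% in this series, but its steps to compound 1 and compound 2 both stay within the scatter, so it cannot be separated from either.

The next compound is compound 4 `O=C(O)[C@H]1CC[C@H](C(=O)N2CC[C@](c3ccc(C(OCC4CCC4)(C(F)(F)F)C(F)(F)F)cc3)(S(=O)(=O)c3ccc(F)cc3)C2)CC1` with the difference from compound 3 being cyclobutyl in place of 2-fluoro-6-methoxyphenyl on a saturated chain carbon bound to an oxygen on a saturated carbon in the form of cyclobutyl in place of 2-fluoro-6-methoxyphenyl on a saturated chain carbon bound to an oxygen on a saturated carbon.

Within the data shown here, three measured steps bear on this only indirectly. They are a number 3 percentage points lower from compound 1 to compound 2 (within the scatter) then a number 7 percentage points higher from compound 1 to compound 3 (within the scatter) and a number 10 percentage points higher from compound 2 to compound 3 (within the scatter) in this set. All three keep a substituted phenyl at this place, and none shows what happens when the aromatic ring is lost.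

No step beyond the scatter is therefore expected in this assay with any confidence. A modest fall is the likelier direction, as compound 3 at 88% leaves little room above it on this read-out. The expected change is a number 10 percentage points lower from compound 3 to compound 4 (within the scatter) on this estimate.

For compound 4 the estimated value is 78% with an expected range from 60% to 92% for now.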

Compound 4, percent of the compound remaining: 39%
Compound 4: middle estimate off by 39 percentage points, on the high side; measured number below the stated range.
By their numbers in this assay, from the lowest: compound 4; then compounds 2, 1 and 3 (each within the scatter of the next).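

In this assay, the place on a saturated chain carbon bound to an oxygen on a saturated carbon proves sensitive to the group it carries once the aromatic ring goes: cyclobutyl gives a large fall against each of the three phenyl compounds (a number 49 percentage points lower from compound 3 to compound 4 (beyond the scatter); a number 39 percentage points lower from compound 2 to compound 4 (beyond the scatter); a number 42 percentage points lower from compound 1 to compound 4 (beyond the scatter)). The earlier compounds shown here changed only the substituents on the phenyl ring, and every step among them stayed within the scatter, so they gave no sign that this place could move the read-out at all. All three new steps point the same way whichever substituted phenyl leaves, and nothing among the data shown gives a reason for the fall.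

Still open, going by these compounds, is whether the fall goes with the loss of aromaticity or with the smaller group, since cyclobutyl differs from 2-fluoro-6-methoxyphenyl in both ring type and heavy-atom count, and cyclohexyl, a six-membered non-aromatic ring of carbon only, would separate the two. Also open, on these data alone, is how unsubstituted phenyl, a pyridyl ring or an open chain such as isobutyl would read at this place.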